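Moving a Methoxy Group Around a Chalcone Ring

The compounds below may be only part of what the source reports. "The series", "measured", "known", "first", "only" and "open" are said of these compounds alone.

Of the compounds shown here, two from one series have been measured in a functional assay on CAL-51 cells (Homo sapiens) for inhibition, read by sulforhodamine B assay, with a stated time of 3 days; a lower number here means a stronger inhibitor of growth, a higher number a weaker inhibitor of growth. Compound 1, with the structure `COc1cccc(/C=C/C(=O)c2ccc(OCc3ccccc3)cc2)c1`, gives 13700 nM in this assay. Compound 2, with the structure `Cc1ccc(COc2ccc(C(=O)/C=C/c3ccccc3)cc2)cc1`, gives 43200 nM in this assay. Of these two numbers, compound 1 has the lower one, and the gap to compound 2 lies beyond the usual scatter, so compound 1 is the stronger inhibitor of growth of the pair.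

The next compound, compound 3, has the structure `COc1ccc(/C=C/C(=O)c2ccc(OCc3ccccc3)cc2)cc1`. It keeps the same atoms as compound 1 but joins them differently: 4-methoxyphenyl in place of 3-methoxyphenyl on a double-bonded chain carbon bound to a double-bonded chain carbon. Among the compounds with values here, no measured pair in this set shows what such a shift of a methoxy group on the shared core does, so there is no direct precedent to lean on.

With the change confined to the position of one methoxy group, the expected step of a 1.1-fold higher number from compound 1 to compound 3 (0.04 log units; within the scatter) is small, not beyond the scatter, in either direction. Compound 3 is therefore expected to give about 15000 nM in this assay, within a range from 5000 nM to 45000 nM.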

Compound 3, concentration for 50% growth inhibition: > 50000 nM
Compound 3 gave a limit, no number; the forecaster's own chance of this, stated with the estimate: 10%; middle value at least 3.3-fold (0.52 log units) away from the limit.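

Moving the methoxy group, with 4-methoxyphenyl in place of 3-methoxyphenyl and every atom of the shared core kept, is not a silent change in this assay: it gives an at least 3.6-fold higher number from compound 1 to compound 3 (0.56 log units; beyond the scatter). Within the data shown here, this is the first direct reading of this position, since compound 1 and compound 2 differ in more than one place and could not isolate the effect of a single group. The full size of the step stays unknown because the result for compound 3 is a limit of the assay and not a number, which makes the step a minimum rather than a measured size: the limit of > 50000 nM in this assay, at which 1 of the 3 values shown sits.

The compounds shown leave open whether the loss of growth inhibition is tied to the methoxy group itself or would appear with any group in that place, as a comparison of 4-hydroxyphenyl, 4-aminophenyl or 4-chlorophenyl on the same core could begin to show. They also cannot say what lies behind the step, since two compounds that differ in one place show only that the position matters, not how it acts.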